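The source may report more compounds than this note shows. Statements on the series, on what has been measured and on what is new or still open speak of the compounds shown alone.

Of the compounds shown here, three have so far been measured in an assay on HEK293 cells for agonist activity at transient receptor potential cation channel subfamily M member 8 (Homo sapiens), read by fluorescence and calcium flux, with a stated time of 15 min; a lower number here means that less compound is needed, a higher number that more compound is needed for the effect. Compound 1, `Cc1ccc(OCC(=O)N(Cc2cccs2)c2cccnc2)cc1`, gives 198 nM in this assay. Compound 2, `CCN(Cc1cccs1)C(=O)COc1ccc(C(C)C)cc1`, gives 397 nM in this assay, and compound 3, `CCN(Cc1ccc(C)s1)C(=O)COc1ccc(C)cc1`, gives 178 nM in this assay. Among these three numbers compound 1 has the second highest; its nearest neighbour is compound 3 and its furthest is compound 2, and both gaps lie within the scatter of the method, so no order among the three can be claimed.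

Compound 4, `COCCN(Cc1cccs1)C(=O)COc1ccc(C)cc1`, has not yet been measured in this assay. It differs from compound 1 in one place: 2-methoxyethyl in place of pyridin-3-yl on an amide-type nitrogen. In compounds 2 and 3 the amide-type nitrogen already carries a saturated chain rather than an aromatic ring, and compound 2 with 397 nM and compound 3 with 178 nM both sit close to compound 1, so a chain on this nitrogen is tolerated in this series. Among the compounds with values here, no measured pair isolates the exact change from compound 1 to compound 4. The account therefore expects the step of a 1.5-fold higher number from compound 1 to compound 4 (0.18 log units; within the scatter) to be small, within or only slightly beyond the scatter, with a mild lean towards a higher number. For compound 4 the expected value in this assay is 300 nM, with a range from 120 nM to 750 nM.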

Compound 4, half-maximal effective concentration: 400 nM
The estimate for compound 4 lay 1.3-fold (0.12 log units) below the measured number; the range from low to high includes it.
By their numbers in this assay, from the lowest: compounds 3, 1, 2 and 4 (each within the scatter of the next, the first and the last beyond it).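

In this assay, within the data shown here, the exchange of pyridin-3-yl for 2-methoxyethyl on the amide-type nitrogen gives the first direct step at this position (a 2.0-fold higher number from compound 1 to compound 4 (0.31 log units; beyond the scatter)), replacing the indirect reading from compounds that differ in more than one place. The step is modest: the nitrogen still accepts a chain with no ring, but the two groups are not interchangeable, as compound 1 needs less compound for the effect than compound 4 does. No measurement bears on the origin of this step.

The compounds shown leave open whether the step follows from the loss of the ring or from the oxygen in the chain; a phenyl or a butyl group on this nitrogen would separate the two. They also leave open how an amine or a carboxylic acid at the end of the chain would read in this assay, and whether the same exchange gives a step of similar size when the other parts of the core of compound 1 are changed.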